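Benzyl for propyl sulfide swap on the triazolopyrimidine series

The source may hold more compounds than are shown below. What is called first, only, known or untested is meant among the compounds shown, and "the series" means these compounds.

Measured so far:
- compound 1, `C/C(=N\Nc1nc(SCc2ccccc2)nc2c1nnn2Cc1ccccc1)c1ccccc1O`: in a functional assay on ECa-109 cells (Homo sapiens) for antiproliferative activity, read by MTT assay, with a stated time of 72 h (on this read-out lower numbers stand for stronger inhibition and higher numbers for weaker inhibition), compound 1 gives 1770 nM
- compound 2, `CCCSc1nc(N/N=C/c2cc(OC)c(OC)c(OC)c2)c2nnn(Cc3ccccc3)c2n1`: in this assay compound 2 gives 4060 nM
- compound 3, `CCCSc1nc(N/N=C(\C)c2ccccc2O)c2nnn(Cc3ccccc3)c2n1`: in this assay compound 3 gives 11100 nM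

Compound 3 and compound 1 differ by one change, (phenyl in place of ethyl on a saturated chain carbon bound to a sulfur), and it brings a 6.3-fold lower number from compound 3 to compound 1 (0.80 log units; beyond the scatter). Compound 2 carries a different hydrazone part than compound 3; the difference between the two cores is not broken down here. Compound 4, `COc1cc(/C=N/Nc2nc(SCc3ccccc3)nc3c2nnn3Cc2ccccc2)cc(OC)c1OC`, is not yet measured; it stands to compound 2 as compound 1 stands to compound 3, the change being (phenyl in place of ethyl on a saturated chain carbon bound to a sulfur), at the same place in both pairs.

If the step seen in the first pair carries over, compound 4 is expected to give 1100 nM in this assay, between 400 nM and 3200 nM. For the measured compounds named here, this expectation rests on compound 2 at 4060 nM together with the single precedent a 6.3-fold lower number from compound 3 to compound 1 (0.80 log units; beyond the scatter), and the expected step is a 3.7-fold lower number from compound 2 to compound 4 (0.57 log units; beyond the scatter), held somewhat short of that precedent since only one pair supports it.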

Compound 4, half-maximal inhibitory concentration: 4400 nM
Compound 4: middle estimate off by 4.0-fold (0.60 log units), on the low side, outside the stated range (above it).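

Putting benzylsulfanyl in place of propylsulfanyl on the core of compound 2 gives a 1.1-fold higher number from compound 2 to compound 4 (0.03 log units; within the scatter) in this assay, so the drop in the number seen on the other core does not carry over. The same change therefore behaves differently on the two cores: the same change on two cores in this assay, a 6.3-fold lower number (0.80 log units; beyond the scatter) from compound 3 to compound 1 and a 1.1-fold higher number (0.03 log units; within the scatter) from compound 2 to compound 4, 6.8-fold (0.83 log units) apart, beyond the scatter of two such steps. This shows that the step cannot be transferred freely between these hydrazone parts, but two pairs do not show which feature of the hydrazone part accounts for the difference, or how the change behaves on any other core.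

Still open, from the compounds shown here alone, is whether the hydroxyl, the methyl on the hydrazone carbon or the methoxy groups set the difference. Also open, going by these compounds, is how a butyl chain or a chain ending in an amine on the sulfur would behave on each core.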